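Exchanging the Indole Amide for a Benzamide

The compounds below may be only part of what the source reports. "The series", "measured", "known", "first", "only" and "open" are said of these compounds alone.

Within the data shown here, compound 3 `CC(C)C[C@H](NC(=O)c1cc2ccccc2[nH]1)C(=O)N[C@H]1CCN(Cc2ccc(OCCCN(C)C)cc2)C1` is the only member of this small set for which an assay on HEK293 cells for binding affinity to Urotensin-2 receptor (Homo sapiens), read by radioligand binding (on this read-out higher numbers stand for weaker inhibition and lower numbers for stronger inhibition), returns a number: compound 3 gives 501 nM. Compound 1 `CN(C)CCCOc1ccc(CN2CC[C@H](NC(=O)c3ccc(C#N)cc3)C2)cc1` comes back from this assay only as a limit, < 10000 nM. Compound 2 `CC(C)C[C@H](NC(=O)c1cc2ccccc2o1)C(=O)N[C@@H]1CCN(Cc2ccc(OCCCN(C)C)cc2)C1` likewise sits at a limit in this assay, < 10000 nM. Among the measured compounds shown here, two of the three entries therefore rest at the limit of < 10000 nM in this assay, at which 2 of the 3 values shown sit, and compound 3 stands alone as the one measured value, so no step between measured compounds is available to set a scale for further changes.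

Compound 4 `CC(C)C[C@H](NC(=O)c1ccccc1)C(=O)N[C@H]1CCN(Cc2ccc(OCCCN(C)C)cc2)C1` differs from compound 3 in one place: phenyl in place of 1H-indol-2-yl on a carbonyl carbon. For the measured compounds named here, no measured step accompanies this change, and the direction can only be guessed from the shape of the set; one expects a modest weakening of binding in this assay, a 3.0-fold higher number from compound 3 to compound 4 (0.48 log units; beyond the scatter), rather than a gain. Compound 4 is accordingly estimated at 1500 nM in this assay, with a range from 300 nM to 8000 nM.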

Compound 4, inhibition constant: 501 nM
Compound 4: the middle estimate sits 3.0-fold (0.48 log units) above what was measured, and the stated range covers the measured number.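

In this assay, replacing 1H-indol-2-yl with phenyl on the carbonyl carbon gives no change at the digits printed from compound 3 to compound 4 (within the scatter). Among these compounds, this is the only step between measured compounds in the set, and it gives the earlier compounds' lone number a first comparison at this place. Across this one pair, the group can go from 9 heavy atoms and 1 hydrogen-bond donor to 6 heavy atoms and 0 hydrogen-bond donors without a change beyond the scatter.

As far as these compounds go, whether a pyridyl ring or a methoxy-substituted phenyl on the same carbonyl carbon would behave alike remains open, as does whether this result holds beyond this single pair. Steps involving the other compounds cannot be read, as the set still rests partly on a limit: the limit of < 10000 nM in this assay, at which 2 of the 4 values shown sit.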